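Nitrile in place of methoxy on the core

The source may report more compounds than this note shows. Statements on the series, on what has been measured and on what is new or still open speak of the compounds shown alone.

Measured compounds in a functional assay (trachea) with Rattus norvegicus as the target; a lower number here means a less potent compound, a higher number a more potent compound, by a factor of ten per unit of this negative logarithm:
compound 1 `COc1ccc2c(c1)C(n1ccccc1=O)=CC(C)(C)O2` — 5.99
compound 2 `CC1(C)C=C(n2ccccc2=O)c2cc(OC(=O)Nc3ccc(F)cc3)ccc2O1` — 4.37
compound 3 `CC1(C)C=C(n2ccccc2=O)c2cc(OC(=O)Nc3ccc(C(F)(F)F)cc3)ccc2O1` — 4.54

Compound 1 gives the highest of the three numbers in this assay; compound 2 and compound 3 both sit well below it. The two measured steps are a number 1.62 log units lower from compound 1 to compound 2 (beyond the scatter) and a number 0.17 log units higher from compound 2 to compound 3 (within the scatter). Both concern the carbamate arm on the oxygen and its aryl substituent, not an exchange of the methoxy itself for another small group.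

Compound 4 `CC1(C)C=C(n2ccccc2=O)c2cc(C#N)ccc2O1` differs from compound 1 by cyano in place of methoxy on an aromatic carbon. Going by the values given here, no measured step bears on this exchange, so only a small change is expected, a step of a number 0.29 log units lower from compound 1 to compound 4 (within the scatter) with wide uncertainty. Compound 4 is estimated at 5.7, within 4.9 to 6.5.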

Compound 4, logarithm of the reciprocal of the active concentration, log(1/C): 7.1
Beside the measured number, compound 4's estimate is 1.40 log units below it; the measured number lies above the stated range.
By their numbers in this assay, from the lowest: compounds 2 and 3 (each within the scatter of the next); then compound 1; then compound 4.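

In this assay, cyano in place of methoxy on this aromatic carbon gives a number 1.11 log units higher from compound 1 to compound 4 (beyond the scatter), so this position can respond strongly to a simple exchange and not only to the carbamate arm. Going by these compounds alone, the earlier steps showed only a loss from compound 1 and a change within the scatter; compound 4 is the first gain over compound 1. Nothing measured here accounts for this gain.

From the compounds shown here alone, whether the gain is particular to cyano stays open. A primary amide, a carboxylic acid or an amine on this carbon would test that.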